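Replacing 4-methylpiperazin-1-yl with isopropoxy: notes on compound 3

A few compounds are considered here, and "the series" means these few. Any claim that something is new, unique, unknown or untested is made for them only; others in the source may bear on it.

Compound 1 `CC(C)(C)n1cc2c(n1)C(=O)CC1(CCN(C(=O)c3cc(-c4ccc(Cl)cc4)nc4ccccc34)CC1)O2`: 630 nM
Compound 2 `CN1CCN(c2cc(C(=O)N3CCC4(CC3)CC(=O)c3nn(C(C)(C)C)cc3O4)c3ccccc3n2)CC1`: 9550 nM

In a functional assay on HepG2 cells (Homo sapiens) for inhibition, read by MTT assay, with a stated time of 72 h (a higher number here means a weaker inhibitor, a lower number a stronger inhibitor), compound 2 holds the higher of the two numbers, at 9550 nM, and is the weaker inhibitor of the pair. The next structure is compound 3 `CC(C)Oc1cc(C(=O)N2CCC3(CC2)CC(=O)c2nn(C(C)(C)C)cc2O3)c2ccccc2n1`, with isopropoxy in place of 4-methylpiperazin-1-yl on an aromatic carbon, next to the ring nitrogen: isopropoxy in place of 4-methylpiperazin-1-yl on an aromatic carbon. Among the compounds with values here, one measured step bears on this carbon: a 15-fold higher number from compound 1 to compound 2 (1.18 log units; beyond the scatter). This large step shows that the group there can shift the number considerably. Within the data shown here, no measured compound carries isopropoxy, so the size of any shift remains uncertain. A moderate to large step toward a lower number is expected, probably stopping short of compound 1. The expected step is a 3.8-fold lower number from compound 2 to compound 3 (0.58 log units; beyond the scatter). In this assay, compound 3 is estimated at 2500 nM, with an expected range of 700 nM to 9000 nM.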

Compound 3, half-maximal inhibitory concentration: 3150 nM
Compound 3: middle estimate off by 1.3-fold (0.10 log units), on the low side; measured number inside the range.
By their numbers in this assay, from the lowest: compound 1; then compound 3; then compound 2.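

In this assay, the isopropoxy group on this aromatic carbon gives a 3.0-fold lower number from compound 2 to compound 3 (0.48 log units; beyond the scatter) and so places compound 3 between the two earlier compounds. The 4-methylpiperazin-1-yl group is therefore not the only replacement for 4-chlorophenyl to raise the number, since the ring-free isopropoxy group also shows a 5.0-fold higher number from compound 1 to compound 3 (0.70 log units; beyond the scatter) even though that rise is the smaller one. Across these three groups, 4-chlorophenyl holds the lowest number and 4-methylpiperazin-1-yl the highest, but nothing available explains this order.

As far as these compounds go, it remains open whether the oxygen link or the isopropyl part sets the number for compound 3, which a methoxy or ethoxy group at this carbon would help to separate. From the compounds shown here alone, it is also open whether an unsubstituted phenyl or a fluorophenyl group would match 4-chlorophenyl.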